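A few compounds are considered here, and "the series" means these few. Any claim that something is new, unique, unknown or untested is made for them only; others in the source may bear on it.

Of the compounds shown here, three sharing the same core have been measured in a physicochemical assay for solubility, measured as kinetic solubility; a lower number here means a less soluble compound, a higher number a more soluble compound. Compound 1 `CNC(=O)c1cc(C(=O)N[C@H]2CC[C@H](O)CC2)n([C@@H](C)c2ccc(Cl)cc2)n1` gives >= 132 ug/mL, which is a limit of the assay rather than a number. Compound 3 `CNC(=O)c1cc(C(=O)NC2CC2)n(Cc2ccccc2)n1` likewise gives >= 155 ug/mL, also a limit. Compound 2 `CNC(=O)c1cc(C(=O)N[C@H]2[C@@H]3C[C@@H](O)C[C@@H]32)n([C@@H](C)c2cccc(Cl)c2)n1` gives 175 ug/mL in this assay. Compound 1 therefore stands at a limit, and nothing in these numbers ranks it against compound 2 or compound 3; all three are soluble. Compound 4 `CNC(=O)c1cc(C(=O)N[C@H]2CC[C@H](O)CC2)n([C@@H](C)c2ccc(C(F)(F)F)cc2)n1` differs from compound 1 in one place: trifluoromethyl in place of chloro on an aromatic carbon. Among the measured compounds shown here, no measured pair shows this change, so the size of its effect is unknown. A modest loss of solubility is expected for compound 4, with an at least 1.7-fold lower number from compound 1 to compound 4 (0.24 log units; that floor lies within the scatter), giving an estimate of 75 ug/mL and a range from 30 ug/mL to 180 ug/mL.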

Compound 4, solubility: >= 175 ug/mL
Compound 4: no number, only a limit (the forecaster's own chance of this, stated with the estimate: 25%); at least 2.3-fold (0.36 log units) between middle value and limit.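

Among the compounds shown here, compound 1 and compound 4 each stand at a limit of this assay rather than at a number, so no step between them can be read. The compounds shown leave open whether trifluoromethyl in place of chloro changes solubility, and in which direction.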